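Fluorobenzyl triazole chalcones: moving the fluorine in the nitro series

The compounds below may be only part of what the source reports. "The series", "measured", "known", "first", "only" and "open" are said of these compounds alone.

Compound 1 `O=C(/C=C/c1ccc(OCc2cn(Cc3cccc(F)c3)nn2)cc1)c1ccc(Br)cc1` gives 34% in a functional assay on HepG2 cells (Homo sapiens) for inhibition, read by MTT assay, with a stated time of 48 h, tested at 10 uM; a lower number here means less inhibition of growth, a higher number more inhibition of growth at the concentration tested. Compound 2 `O=C(/C=C/c1ccc(OCc2cn(Cc3ccc(F)cc3)nn2)cc1)c1ccc(Br)cc1` gives 22% in this assay, the change being 4-fluorophenyl in place of 3-fluorophenyl on a saturated chain carbon bound to an aromatic nitrogen and the step of a number 12 percentage points lower from compound 1 to compound 2 (beyond the scatter). Compound 3 `O=C(/C=C/c1ccc(OCc2cn(Cc3cccc(F)c3)nn2)cc1)c1ccc([N+](=O)[O-])cc1` gives 43% in this assay; from compound 1 the change is nitro in place of bromo on an aromatic carbon and the step is a number 9 percentage points higher from compound 1 to compound 3 (within the scatter). Compound 4 `O=C(/C=C/c1ccc(OCc2cn(Cc3ccc(F)cc3)nn2)cc1)c1ccc([N+](=O)[O-])cc1` is not yet measured. Its difference from compound 3 is 4-fluorophenyl in place of 3-fluorophenyl on a saturated chain carbon bound to an aromatic nitrogen, the same change as from compound 1 to compound 2, made on a core that differs by nitro in place of bromo on an aromatic carbon. Because the earlier step is a number 12 percentage points lower from compound 1 to compound 2 (beyond the scatter), a similar step a number 12 percentage points lower from compound 3 to compound 4 (beyond the scatter) is expected here. Compound 4 is therefore estimated at 31% in this assay, most likely between 18% and 44%.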

Compound 4, percent growth inhibition at one concentration: 25%
Beside the measured number, compound 4's estimate is 6 percentage points above it; the measured number falls inside the stated range.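

In this assay, 4-fluorophenyl in place of 3-fluorophenyl gives a number 18 percentage points lower from compound 3 to compound 4 (beyond the scatter), and the size of this step carries over between the core with bromo and the core with nitro: the same change on two cores in this assay, a number 12 percentage points lower (beyond the scatter) from compound 1 to compound 2 and a number 18 percentage points lower (beyond the scatter) from compound 3 to compound 4, 6 percentage points apart, within the scatter of two such steps. Nitro in place of bromo, read on the 4-fluorobenzyl pair, gives a number 3 percentage points higher from compound 2 to compound 4 (within the scatter), which agrees with the same change on the 3-fluorobenzyl pair: the same change on two cores in this assay, a number 9 percentage points higher (within the scatter) from compound 1 to compound 3 and a number 3 percentage points higher (within the scatter) from compound 2 to compound 4, 6 percentage points apart, within the scatter of two such steps. This supports carrying the fluorine change between these two cores only; it shows nothing about any other core, and it does not explain why the number moves.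

From the compounds shown here alone, whether the step holds with an amine or a carboxylic acid in place of bromo or nitro remains open. Going by these compounds, an unsubstituted benzyl or a 4-chlorobenzyl on the triazole nitrogen also remains open.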